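Topoisomerase series: hydroxy to methoxy on compound 2

The source may hold more compounds than are shown below. What is called first, only, known or untested is meant among the compounds shown, and "the series" means these compounds.

Measured so far:
compound 1 `COc1ccc(-c2cc3cc(C)ccc3c(-c3cccc(O)c3)n2)c(C)c1` — 73.4%
compound 2 `COc1ccc(-c2cc3cc(C)ccc3c(-c3cccc(O)c3)n2)cc1OC` — 1.7%

In an assay on isolated protein for inhibition of DNA topoisomerase 1 (Homo sapiens), with a stated time of 30 min, tested at 100 uM (on this read-out lower numbers stand for a weaker effect and higher numbers for a stronger effect at the one concentration tested), compound 1 gives 73.4% while compound 2 gives 1.7%. Compound 2 thus stands lowest of the two numbers; its nearest neighbour, compound 1, sits higher by a gap beyond the scatter. Compound 3 `COc1cccc(-c2nc(-c3ccc(OC)c(OC)c3)cc3cc(C)ccc23)c1` is still to be measured in this assay. It differs from compound 2 by methyl in place of hydrogen on an oxygen on an aromatic ring. Within the data shown here, no step between measured compounds covers this change, so no direction follows from them; with compound 2 already near the bottom of the read-out, the step is expected to be small, a number 3.3 percentage points higher from compound 2 to compound 3 (within the scatter), none beyond the scatter. For compound 3 the value in this assay is estimated at 5%, within 0% to 25%.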

Compound 3, a percentage reported as inhibition, at one concentration (the size of the read-out at that concentration, not a potency): 2.9%
Beside the measured number, compound 3's estimate is 2.1 percentage points above it; measured number inside the range.
By their numbers in this assay, from the lowest: compounds 2 and 3 (each within the scatter of the next); then compound 1.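

In this assay, hydroxy to methoxy on the aromatic ring gives a number 1.2 percentage points higher from compound 2 to compound 3 (within the scatter), the first step measured at this position. With the 3,4-dimethoxy pattern of compound 2 retained, the free hydroxy and its methyl ether therefore cannot be told apart, and both compounds remain near the bottom of the read-out. No supporting data bear on this result.

From the compounds shown here alone, since this step starts so close to the bottom, the same change on the more active compound 1 remains open. So does an amine or a longer chain such as ethoxy in this place.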